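Imidazolyl to Thiazolyl on a Bicyclic Thromboxane Synthase Scaffold

This account rests on a few compounds, and the source may have more. Where it says the series, first, only, none or still open, it means among the compounds named here.

Three compounds have numbers in an assay on isolated protein (Oryctolagus cuniculus) with Thromboxane-A synthase (Homo sapiens) as the target, tested at 1 uM; on this read-out higher numbers stand for more inhibition at the one concentration tested (going by the name of the read-out) and lower numbers for less inhibition. Compound 1 `CC(=O)Cn1nc(-c2cccnc2)c2ccccc2c1=O` gives 13%, compound 2 `O=c1c2ccccc2c(-c2cccnc2)nn1CCO` gives 69%, and compound 3 `CCn1nc(-n2ccnc2)c2ccccc2c1=O` gives 53%. Compound 3 stands second highest of the three: compound 2 is higher beyond the scatter, compound 1 lower beyond the scatter. For the measured compounds named here, the one single-place step known, a number 56 percentage points higher from compound 1 to compound 2 (beyond the scatter), concerns the side chain on the ring nitrogen, not the aryl group, so it does not bear on the change to compound 4 `CCn1nc(-c2nccs2)c2ccccc2c1=O`, namely (1,3-thiazol-2-yl in place of 1H-imidazol-1-yl on an aromatic carbon). Going by the values given here, with no step informing it, the expectation is a number 13 percentage points lower from compound 3 to compound 4 (beyond the scatter), and compound 4 is estimated at 40%, from 10% to 70%.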

Compound 4, a percentage reported as inhibition, at one concentration (the size of the read-out at that concentration, not a potency): 4%
The estimate for compound 4 lay 36 percentage points above the measured number, and the stated range ends above it.
By their numbers in this assay, from the lowest: compounds 4 and 1 (each within the scatter of the next); then compound 3; then compound 2.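

Replacing 1H-imidazol-1-yl with 1,3-thiazol-2-yl on this aromatic carbon gives a number 49 percentage points lower from compound 3 to compound 4 (beyond the scatter) in this assay. At this position, therefore, the result depends strongly on which five-membered aromatic ring is present, although both groups have the same counts of heavy atoms, hydrogen-bond donors and acceptors. Nothing measured here accounts for the drop. Still open, from the compounds shown here alone, is whether a 1,3-oxazol-2-yl or 1H-imidazol-2-yl group at this position would track compound 3 or compound 4. Going by these compounds, it is also open whether the size of this step holds with a different side chain on the ring nitrogen.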